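The source may hold more compounds than are shown below. What is called first, only, known or untested is meant among the compounds shown, and "the series" means these compounds.

In a toxicity assay on Huh-7 cells (Homo sapiens) for cytotoxicity, read by CCK-8 assay, with a stated time of 24 h (on this read-out higher numbers stand for lower toxicity in this test and lower numbers for higher toxicity in this test), compound 1 `O=c1cc(-c2ccccc2)oc2c(-c3cccc(F)c3)c(O)c(O)c(O)c12` gives > 100000 nM, which is a limit and not a number. Compound 2 `Oc1c(O)c(O)c2c(=S)cc(-c3ccccc3)oc2c1-c1ccc(F)cc1` gives > 100000 nM, again a limit. Compound 3 `Oc1c(O)c(O)c2c(=S)cc(-c3ccccc3)oc2c1-c1cccc(F)c1` gives > 100000 nM, also a limit, so it has no exact place on the scale. The whole picture so far is the limit of > 100000 nM in this assay, at which 3 of the 3 values shown sit.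

Compound 4 `Oc1cc2oc(-c3ccccc3)cc(=S)c2c(O)c1O` differs from compound 3 by hydrogen in place of 3-fluorophenyl on an aromatic carbon. For the measured compounds named here, the only measured step that bears on this is a step that the two limits leave unreadable from compound 2 to compound 3. It swaps 3-fluorophenyl for 4-fluorophenyl rather than removing the group, and it offers no size to carry over.

With only the limit of > 100000 nM in this assay, at which 3 of the 3 values shown sit, to go on, no step beyond the usual scatter is expected in this assay, although the data cannot rule one out. The expected result is a number no higher from compound 3 to compound 4 (the limit leaves the size open). For compound 4 the estimated value is 100000 nM, with an expected range from 40000 nM to 250000 nM, and a report of only a limit is the likeliest outcome.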

Compound 4, half-maximal cytotoxic concentration: > 100000 nM
Compound 4: only a limit was reported; the forecaster's own chance of this, stated with the estimate: 75%; the middle value lies on the limit itself.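

Compound 4 also gives only a limit, so no step can be read from compound 2 or compound 3 to compound 4, because the results offer no exact numbers: the limit of > 100000 nM in this assay, at which 4 of the 4 values shown sit.

The compounds shown leave open whether moving or removing the fluorophenyl group changes the result in this assay at all.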